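Swapping a branched alkyl tail for a benzyl tail

A few compounds are considered here, and "the series" means these few. Any claim that something is new, unique, unknown or untested is made for them only; others in the source may bear on it.

Measured compounds:
compound 1 `CC(C)CCC(=O)N[C@@H](C(=O)N1CCC(c2ccc(Cl)cc2)CC1)C(C)C`, 26 nM
compound 2 `CC(C)C(NC(=O)c1ccccc1)C(=O)N1CCC(c2ccc(F)cc2)CC1`, 423 nM
compound 3 `CCCC(NC(=O)c1ccccc1C)C(=O)N1CCC(c2ccc(Cl)cc2)CC1`, 152 nM

In an assay on THP-1 cells for displacement of a labelled ligand from C-C chemokine receptor type 1 (Homo sapiens) (a higher number here means a weaker inhibitor, a lower number a stronger inhibitor), compound 1 gives 26 nM, the lowest number of the three and so the strongest inhibitor here. Compound 3 stands next with 152 nM, and compound 2 is furthest away with 423 nM; both of these gaps lie beyond the usual scatter. Compounds 2 and 3 differ from compound 1 in more than one place, so their values can only be read side by side, not as single steps.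

Compound 4 `CC(C)[C@@H](NC(=O)CCCc1ccccc1)C(=O)N1CCC(c2ccc(Cl)cc2)CC1` has not yet been measured in this assay. Compared with compound 1 the change is benzyl in place of isopropyl on a saturated chain carbon, two bonds along the chain from a carbonyl carbon, that is, an aromatic ring now hangs at the end of the acyl chain in place of a branched alkyl end. The two compounds that carry an aromatic acyl group, compound 2 and compound 3, show weaker numbers than compound 1, but their other changes blur that comparison. A step of a 2.1-fold higher number from compound 1 to compound 4 (0.33 log units; beyond the scatter) is expected, toward a somewhat higher number, close to the edge of the scatter. Compound 4 is estimated at 55 nM, within a range from 15 nM to 200 nM.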

Compound 4, half-maximal inhibitory concentration: 95 nM
For compound 4 the middle estimate is 1.7-fold (0.24 log units) below the measured one; the measured number falls inside the stated range.
By their numbers in this assay, from the lowest: compound 1; then compounds 4 and 3 (each within the scatter of the next); then compound 2.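

In this assay, within the data shown here, this is the first comparison that changes only one place, and benzyl in place of isopropyl gives a 3.7-fold higher number from compound 1 to compound 4 (0.56 log units; beyond the scatter). It shows that the end of the acyl chain affects the number, and that the larger group, with seven heavy atoms and an aromatic ring in place of three carbons and no ring, costs only a modest loss: compound 4 still reads 95 nM. Nothing at hand shows why the number moves in this direction.

The compounds shown leave open whether the aromatic ring itself matters or only the size of the chain end, a question that a cyclohexyl end could help to settle. They also leave open how an amine or a carboxylic acid at that same chain end would read.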